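Silyl-protected cyclopentenone series: phenyl swap, cytotoxicity notes

The source may hold more compounds than are shown below. What is called first, only, known or untested is meant among the compounds shown, and "the series" means these compounds.

Compound 1 `COc1ccc(C2=C(c3cc(OC)c(OC)c(OC)c3)C(=O)CC2O[SiH2]C(C)(C)C)cc1OC` has been run in an ADME assay on DU-145 cells (Homo sapiens) for cytotoxicity, read by MTT assay, with a stated time of 72 h; a lower number here means a stronger inhibitor, a higher number a weaker inhibitor. In this assay compound 1 gives only a limit, > 100 ug/mL, and not a number. Compound 2 `COc1ccc(C2=C(c3cc(OC)c(OC)c(OC)c3)C(=O)C(OC(C)=O)C2)cc1`, a second member of the series, likewise returns only a limit in this assay, > 100 ug/mL. Neither result is a number, so compound 1 cannot be placed against compound 2 on the shown values; both simply sit at the limit of > 100 ug/mL in this assay, at which 2 of the 2 values shown sit. For the measured compounds named here, no pair of measured compounds differs in a single place, so no measured step is available in this assay.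

Compound 3 `COc1cc(C2=C(c3ccccc3)C(O[SiH2]C(C)(C)C)CC2=O)cc(OC)c1OC` is still to be measured in this assay. It differs from compound 1 by phenyl in place of 3,4-dimethoxyphenyl on a double-bonded ring carbon. Because both shown values rest at the limit of > 100 ug/mL in this assay, at which 2 of the 2 values shown sit, the step from compound 1 to compound 3 is expected to be none beyond the scatter, with a step that the limit leaves unreadable from compound 1 to compound 3 as the estimated change. For compound 3 the estimate in this assay is 120 ug/mL, with a range from 40 ug/mL to 300 ug/mL, and a limit rather than a number is the likelier outcome.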

Compound 3, half-maximal inhibitory concentration: > 100 ug/mL
Compound 3: only a limit was reported (the forecaster's own chance of this, stated with the estimate: 70%); the middle value is on the limit's open side.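

In this assay compound 3 gives > 100 ug/mL, a limit and not a number. For the compounds shown here, compound 1 also rests on a limit, and no step from compound 1 to compound 3 can be read for phenyl in place of 3,4-dimethoxyphenyl. The compounds shown leave open whether any member of this series gives a number in this assay, as all values share one ceiling: the limit of > 100 ug/mL in this assay, at which 3 of the 3 values shown sit.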